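The compounds below may be only part of what the source reports. "The series", "measured", "known", "first", "only" and "open" are said of these compounds alone.

Of the compounds shown here, three built on one shared core have been measured in an assay on cells for inhibition of MAP kinase-interacting serine/threonine-protein kinase 2 (Homo sapiens), read by mobility shift assay, with stated times of 10 min and 60 min, in the presence of a further agent that is not named here; on this read-out lower numbers stand for stronger inhibition and higher numbers for weaker inhibition. Compound 1 `CC(C)Oc1cc(-c2cncc(-c3cnn(C4COC4)c3)c2)ccc1C(N)=O` gives 89 nM in this assay. Compound 2 `CC(C)Oc1cc(-c2cncc(-c3cnn(C(C)C)c3)c2)ccc1C(N)=O` gives 42 nM, and compound 3 `Cc1c(-c2cncc(-c3ccc(C(N)=O)c(OC(C)C)c3)c2)cnn1C` gives 120 nM. Of the three numbers, compound 3 stands highest: it sits close to compound 1, with a 1.3-fold higher number from compound 1 to compound 3 (0.13 log units; within the scatter), and further from compound 2, with a 2.9-fold higher number from compound 2 to compound 3 (0.46 log units; beyond the scatter). The step of a 2.1-fold lower number from compound 1 to compound 2 (0.33 log units; beyond the scatter) shows what exchanging only the group on the ring nitrogen did.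

Compound 4 `CC(C)Oc1cc(-c2cncc(-c3cnn(C)c3)c2)ccc1C(N)=O` differs from compound 3 in one place: hydrogen in place of methyl on an aromatic carbon. Among the compounds with values here, no measured step removes just this methyl. The two steps that end at compound 3 each exchange the whole group on the aromatic carbon, and they run from within the scatter to a modest rise in number, so they give no more than an indirect guide. On that basis a small step is expected, if any, with the number for compound 4 somewhat lower than for compound 3 or unchanged within the scatter. Compound 4 is therefore expected to give about 80 nM in this assay. The estimated range for compound 4 runs from 35 nM to 180 nM. This estimate means a step of a 1.5-fold lower number from compound 3 to compound 4 (0.18 log units; within the scatter).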

Compound 4, half-maximal inhibitory concentration: 160 nM
For compound 4 the middle estimate is 2.0-fold (0.30 log units) below the measured one, and the stated range covers the measured number.
By their numbers in this assay, from the lowest: compound 2; then compounds 1, 3 and 4 (each within the scatter of the next).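

In this assay, within the data shown here, the first direct reading of hydrogen in place of methyl on the aromatic carbon next to the ring nitrogen gives a 1.3-fold higher number from compound 3 to compound 4 (0.12 log units; within the scatter) so this assay separates neither group from the other at this position. Compound 4 also gives the group on the ring nitrogen a third comparison: methyl in place of isopropyl gives a 3.8-fold higher number from compound 2 to compound 4 (0.58 log units; beyond the scatter) and methyl in place of oxetan-3-yl gives a 1.8-fold higher number from compound 1 to compound 4 (0.25 log units; within the scatter) so among these three groups only the isopropyl-to-methyl exchange is resolved beyond the scatter, and modestly. Nothing available here accounts for any of these steps.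

The compounds shown leave open whether the step at the aromatic carbon would stay as small with isopropyl rather than methyl on the ring nitrogen. They also leave open how an ethyl or a tert-butyl group on the ring nitrogen, or a fluorine or an amine on the aromatic carbon, would read in this assay against the groups compared so far.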